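A Methoxy Group Added to Compound 1: An Expectation

The source may report more compounds than this note shows. Statements on the series, on what has been measured and on what is new or still open speak of the compounds shown alone.

Measured in a functional assay on TK-10 cells (Homo sapiens) for inhibition, read by sulforhodamine B assay, with a stated time of 48 h; on this read-out lower numbers stand for stronger inhibition of growth and higher numbers for weaker inhibition of growth:
Compound 1 `COc1ccc(-c2[nH]c3ccccc3c2/C=C(\C#N)S(=O)(=O)c2ccccc2)cc1` gives 4800 nM
Compound 2 `COc1ccc2[nH]c(-c3ccccc3)c(C=C(C#N)C#N)c2c1` gives 5100 nM
Compound 3 `CCOC(=O)C(=Cc1c(-c2ccccc2)[nH]c2ccccc12)C(=O)OCC` gives 13600 nM

Compound 1 has the lowest number of the three in this assay. Its number and that of compound 2 lie within the usual scatter of repeated measurements, so the two cannot be told apart on this read-out. Compound 3 stands apart, with a number beyond the scatter above that of compound 1.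

Compound 4 `COc1ccc(-c2[nH]c3ccc(OC)cc3c2/C=C(\C#N)S(=O)(=O)c2ccccc2)cc1` is not yet measured. It differs from compound 1 in one place: methoxy in place of hydrogen on an aromatic carbon. Among the compounds with values here, no pair of measured compounds shows this same change, so no measured step can guide the expectation. The change is small in heavy atoms and leaves the rest of compound 1 untouched, and the expected step in this assay from compound 1 to compound 4 is therefore small, in no firm direction, and most likely within the scatter, as a 1.1-fold lower number from compound 1 to compound 4 (0.03 log units; within the scatter). Compound 4 is thus expected to give about 4500 nM, with a range from 2000 nM to 10000 nM.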

Compound 4, concentration for 50% growth inhibition: 5000 nM
Compound 4: the middle estimate sits 1.1-fold (0.05 log units) below what was measured, within the range that was stated.
By their numbers in this assay, from the lowest: compounds 1, 4 and 2 (each within the scatter of the next); then compound 3.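

In this assay putting methoxy in place of hydrogen on this aromatic carbon gives a 1.0-fold higher number from compound 1 to compound 4 (0.02 log units; within the scatter) and so makes no difference that this read-out can detect. Within the data shown here, this is the first pair of compounds here that differ in one place, and it shows that the core of compound 1 can carry these 2 extra heavy atoms at this carbon, on the six-membered aromatic ring of carbon only, without moving out of the scatter. No measurement here accounts for this result.

From the compounds shown here alone, whether other groups would behave the same way at this carbon remains open, since a single methoxy says nothing about an amine, a carboxylic acid or a longer chain such as butoxy. The compounds shown also do not tell whether methoxy on another carbon of this ring would read the same.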